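A Fluorine Step Revisited on a Second Core

A few compounds are considered here, and "the series" means these few. Any claim that something is new, unique, unknown or untested is made for them only; others in the source may bear on it.

Compound 1 `Cc1cc(=O)n(-c2ccc(Br)cc2F)nc1C(=O)Nc1ccc(Oc2ncnc3[nH]ccc23)cc1` was examined in a functional assay on HepG2 cells (Homo sapiens) for cytotoxicity, read by MTT assay, with a stated time of 72 h; on this read-out lower numbers stand for stronger inhibition and higher numbers for weaker inhibition; in this assay compound 1 gives 3660 nM. Compound 2 `Cc1cc(=O)n(-c2ccc(Br)cc2F)nc1C(=O)Nc1ccc(Oc2ncnc3[nH]ccc23)c(F)c1` differs from compound 1 in one place, (fluoro in place of hydrogen on an aromatic carbon), and in this assay compound 2 gives 32000 nM. The step between them is an 8.7-fold higher number from compound 1 to compound 2 (0.94 log units; beyond the scatter), so the added fluoro goes with weaker inhibition on this pair.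

Compound 3 `Cc1cc(=O)n(-c2ccccc2OC(F)(F)F)nc1C(=O)Nc1ccc(Oc2ncnc3c2ccn3C)cc1` rests on a different core; how that core differs from the core of compound 1 is not broken down here. In this assay compound 3 gives only a limit, > 60000 nM, and this is the limit of > 60000 nM in this assay, at which 1 of the 3 values shown sits.

Compound 4 `Cc1cc(=O)n(-c2ccccc2OC(F)(F)F)nc1C(=O)Nc1ccc(Oc2ncnc3c2ccn3C)c(F)c1` has not yet been measured in this assay. It differs from compound 3 in one place, (fluoro in place of hydrogen on an aromatic carbon), which is the same change as that between compound 1 and compound 2, at a place described in the same words. Because compound 3 already sits at the limit of > 60000 nM in this assay, at which 1 of the 3 values shown sits, a change that raised the number on the first pair is expected to leave compound 4 beyond the reach of the assay as well. The expected step is estimated as a step that the limit leaves unreadable from compound 3 to compound 4, set beside the measured 8.7-fold higher number from compound 1 to compound 2 (0.94 log units; beyond the scatter). Compound 4 is therefore expected to give about 150000 nM in this assay, with a range from 60000 nM to 600000 nM, and the assay is most likely to report only a limit for it.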

Compound 4, half-maximal inhibitory concentration: > 60000 nM
Compound 4 gave a limit, no number; the forecaster's own chance of this, stated with the estimate: 90%; the middle value is on the limit's open side.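

In this assay compound 4 gives > 60000 nM, which is a limit and not a number. Compound 3 gives only a limit too, so no step between compound 3 and compound 4 can be read; both sit at the same ceiling: the limit of > 60000 nM in this assay, at which 2 of the 4 values shown sit.

The compounds shown leave open whether the added fluoro goes with weaker inhibition on the core of compound 3, as it does on the core of compound 1.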